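The source may hold more compounds than are shown below. What is called first, only, known or untested is meant among the compounds shown, and "the series" means these compounds.

In an ADME assay on J774 cells (Mus musculus) for cytotoxicity (a lower number here means that less compound is needed, a higher number that more compound is needed for the effect), compound 1 `COC(=O)c1c[nH]c2cc(OCCOc3ccccc3)ccc2c1=O` gives > 20000 nM, which is a limit and not a number. Compound 2 `CCCCc1cc2c(=O)c(C(=O)OC)c[nH]c2cc1OCCOc1ccccc1` gives > 20000 nM, also a limit. Among the compounds with values here, the only measured step, a step that the two limits leave unreadable from compound 1 to compound 2, puts butyl in place of hydrogen on an aromatic carbon and has no readable size. Compound 3 `COC(=O)c1c[nH]c2cc(OCCCc3ccccc3)ccc2c1=O` differs from compound 1 by benzyl in place of phenoxy on a saturated chain carbon, two bonds along the chain from an oxygen on an aromatic ring: benzyl in place of phenoxy on a saturated chain carbon. The evidence is the limit of > 20000 nM in this assay, at which 2 of the 2 values shown sit, so no step beyond the scatter is expected in this assay, in either direction. Compound 3 is expected at 20000 nM, within an estimated range from 9000 nM to 40000 nM. This estimate means an expected a number no higher from compound 1 to compound 3 (the limit leaves the size open).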

Compound 3, half-maximal effective concentration: 1480 nM
Compound 3: the middle estimate sits 14-fold (1.13 log units) above what was measured; the measured number lies below the stated range.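

In this assay, benzyl in place of phenoxy on the saturated chain carbon gives an at least 13-fold lower number from compound 1 to compound 3 (1.13 log units; beyond the scatter). Within the data shown here, the earlier step between compound 1 and compound 2 cannot be read, so this is the first evidence that the assay responds to a change in the core's side chain, here one where an oxygen gives way to carbon. Compound 3 alone has a readable number, the other two values being limits: the limit of > 20000 nM in this assay, at which 2 of the 3 values shown sit.

Going by these compounds, whether the same change would act alike on compound 2 stays open. So does what an amine or a longer chain would give at this place.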